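The source may report more compounds than this note shows. Statements on the series, on what has been measured and on what is new or still open speak of the compounds shown alone.

Measured compounds and values in an ADME assay on HEK293 cells (Homo sapiens) for cytotoxicity, read by resazurin assay, with a stated time of 48 h; a higher number here means that more compound is tolerated, a lower number that less compound is tolerated:

- compound 1, `O=S(=O)(Nc1ccc2oc(-c3ccccc3)nc2c1)c1ccccc1O`: 33000 nM
- compound 2, `O=S(=O)(Nc1ccc2oc(-c3ccccc3)nc2c1)c1ccc(Cl)c(Cl)c1`: 71000 nM
- compound 3, `O=S(=O)(Nc1ccc(-c2nc3ccccc3o2)cc1)c1cccc(Cl)c1`: > 100000 nM

The three share a common core; they differ in the aryl group on the sulfonyl sulfur and in where the sulfonamide sits on that core. Going by the values given here, the only measured step between single-point neighbours is a 2.2-fold higher number from compound 1 to compound 2 (0.33 log units; beyond the scatter), a modest shift in the direction of more compound being tolerated. For compound 3 the value is not a number but a limit of this assay, as recorded in the limit of > 100000 nM in this assay, at which 1 of the 3 values shown sits; compound 3 therefore stands at the edge of what the assay reports, and only a lower bound is known for it.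

Compound 4, `O=S(=O)(Nc1ccc(-c2nc3ccccc3o2)cc1)c1ccc(F)cc1`, differs from compound 3 in one place: 4-fluorophenyl in place of 3-chlorophenyl on a sulfonyl sulfur. Among the compounds with values here, the step from compound 1 to compound 2 is the only measured change of the aryl on the sulfonyl sulfur and it stayed modest, so the change from compound 3 to compound 4 is expected to give a step of a number no higher from compound 3 to compound 4 (the limit leaves the size open) in this assay, that is none beyond the scatter. Compound 4 is thus estimated at 100000 nM, with a range from 40000 nM to 250000 nM, and a fair chance that only a limit is reported again.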

Compound 4, half-maximal cytotoxic concentration: > 100000 nM
Compound 4 gave a limit, no number; the forecaster's own chance of this, stated with the estimate: 55%; the middle value lies on the limit itself.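

Compound 4 gives > 100000 nM in this assay, a limit and not a number. Going by these compounds alone, compound 3 also stands at a limit, so no step between compound 3 and compound 4 can be read. Still open, as far as these compounds go, is how far either compound lies beyond that limit.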